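A few compounds are considered here, and "the series" means these few. Any claim that something is new, unique, unknown or untested is made for them only; others in the source may bear on it.

Working notes on the series. Compound 1 `Cc1ccc2nc(Nc3nc(Nc4ccc(S(N)(=O)=O)cc4)ncc3F)sc2c1` and compound 2 `NS(=O)(=O)c1ccc(Nc2ncc(F)c(Nc3nc4ccccc4s3)n2)cc1` share a core and differ at one aromatic carbon. In a functional assay on HCT-116 cells (Homo sapiens) for antiproliferative activity, read by MTT assay, with a stated time of 48 h (a lower number here means a stronger inhibitor, a higher number a weaker inhibitor), compound 1 gives 1460 nM and compound 2 gives 3260 nM. The change between them is methyl in place of hydrogen on an aromatic carbon and the step it makes is a 2.2-fold lower number from compound 2 to compound 1 (0.35 log units; beyond the scatter). Compound 3 `CS(=O)(=O)c1ccc(Nc2nccc(Nc3nc4ccccc4s3)n2)cc1` carries a different core; how it differs from the core of compound 2 is not broken down here. In this assay compound 3 gives 8370 nM, the highest number of the three measured compounds. Compound 4 `Cc1ccc2nc(Nc3ccnc(Nc4ccc(S(C)(=O)=O)cc4)n3)sc2c1` is compound 3 with the same change applied: methyl in place of hydrogen on an aromatic carbon. The place lines of the two changes agree word for word, so the change is the same rather than merely of the same kind. On the basis of the step from compound 2 to compound 1, a step of similar size is expected from compound 3 to compound 4, namely a 2.1-fold lower number from compound 3 to compound 4 (0.32 log units; beyond the scatter) in this assay. The value expected for compound 4 in this assay is 4000 nM, likely between 2000 nM and 8500 nM.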

Compound 4, half-maximal inhibitory concentration: 1750 nM
Compound 4: the middle estimate sits 2.3-fold (0.36 log units) above what was measured; measured number outside the range, below it.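

In this assay, methyl in place of hydrogen on an aromatic carbon lowers the number on the second core as well, with a 4.8-fold lower number from compound 3 to compound 4 (0.68 log units; beyond the scatter), and the two steps do not differ beyond what repeated measurements allow: the same change on two cores in this assay, a 2.2-fold lower number (0.35 log units; beyond the scatter) from compound 2 to compound 1 and a 4.8-fold lower number (0.68 log units; beyond the scatter) from compound 3 to compound 4, 2.1-fold (0.33 log units) apart, within the scatter of two such steps

The change therefore carries over between these two cores in direction and, within the scatter, in size, so the larger second step should not be read as a stronger effect on that core. Two pairs do not show that the step would hold on any further core, and they do not explain why the number falls.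

Open, from the compounds shown here alone, is whether ethyl, a longer chain, methoxy, chlorine or an amine in place of that hydrogen would move the number in the same direction as methyl. Also open, going by these compounds, is which part of the difference between the two cores, if any, bears on the size of the step.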